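The source may hold more compounds than are shown below. What is called first, only, known or untested is meant among the compounds shown, and "the series" means these compounds.

Among the compounds with values here, in a functional assay (muscle tissue) with Cavia porcellus as the target (on this read-out lower numbers stand for an effect already at smaller amounts and higher numbers for an effect only at larger amounts of compound), compound 2 `COC(=O)C1=C(C)N=C(C)/C(=C(\O)OC)C1c1ccccc1C(F)(F)F` gives 1.51 nM, the lower of the two numbers so far, while compound 1 `COC(=O)C1=C(C)N=C(C)/C(=C(\O)OC)C1c1ccccc1I` gives 46.8 nM. Compound 3 `CCOc1ccccc1C1C(C(=O)OC)=C(C)N=C(C)/C1=C(\O)OC` carries ethoxy in place of trifluoromethyl on an aromatic carbon, ortho to a large group (ethoxy in place of trifluoromethyl on an aromatic carbon). Within the data shown here, the only measured step at this place is a 31-fold lower number from compound 1 to compound 2 (1.49 log units; beyond the scatter), which is large, so the read-out can respond strongly to the group there. Among the measured compounds shown here, no ethoxy analogue has been measured yet. A large step towards a higher number is expected, namely a 20-fold higher number from compound 2 to compound 3 (1.30 log units; beyond the scatter). For compound 3 the estimated value is 30 nM, with an expected range of 6 nM to 150 nM.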

Compound 3, half-maximal effective concentration: 110 nM
The estimate for compound 3 lay 3.7-fold (0.56 log units) below the measured number; the range from low to high includes it.
By their numbers in this assay, from the lowest: compound 2; then compound 1; then compound 3.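

In this assay, ethoxy in place of trifluoromethyl on the aromatic carbon gives a 73-fold higher number from compound 2 to compound 3 (1.86 log units; beyond the scatter), so the high sensitivity at this position also holds for a third group. Ethoxy in place of iodo gives only a 2.4-fold higher number from compound 1 to compound 3 (0.37 log units; beyond the scatter), so among these three groups, trifluoromethyl stands well apart, while ethoxy and iodo lie much closer together. Nothing available explains this separation. On these data alone, whether methoxy or a nitrile at this place would fall nearer trifluoromethyl or nearer ethoxy and iodo remains open.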